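Swapping the pendant aryl group on a shared anticancer scaffold

A few compounds are considered here, and "the series" means these few. Any claim that something is new, unique, unknown or untested is made for them only; others in the source may bear on it.

Of the compounds shown here, three of one series have been tested in a functional assay on A549 cells (Homo sapiens) for cytotoxicity, read by MTT assay; on this read-out lower numbers stand for stronger inhibition and higher numbers for weaker inhibition. Compound 1 `O=c1c(-c2nnc(-c3ccc(Nc4ccccc4)cc3)o2)cn(C2CC2)c2cc(N3CCNCC3)c(F)cc12` gives 52 ug/mL in this assay. Compound 2 `CCn1cc(-c2nnc(COc3cccc4ccccc34)o2)c(=O)c2cc(F)c(N3CCNCC3)cc21` gives 127 ug/mL, and compound 3 `O=c1c(-c2nnc(COc3cccc4ccccc34)o2)cn(C2CC2)c2cc(N3CCNCC3)c(F)cc12` gives 96.2 ug/mL. Going by the values given here, compound 2 thus shows the highest of the three numbers: its nearest neighbour is compound 3, and the only single-point step measured, a 1.3-fold lower number from compound 2 to compound 3 (0.12 log units; within the scatter), stays within the scatter. Compound 1 is further away, beyond the scatter, but compound 1 and compound 2 differ at more than one place, so only their two values can be set side by side.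

The unmeasured compound 4 `CCn1cc(-c2nnc(-c3ccc([N+](=O)[O-])cc3)o2)c(=O)c2cc(F)c(N3CCNCC3)cc21` differs from compound 2 at the five-membered ring: 4-nitrophenyl in place of ((naphthalen-1-yl)oxy)methyl on an aromatic carbon. Among the compounds with values here, no measured step touches this position; the one known step changes a different group and is small. Within the data shown here, the only hint is that compound 1, which also carries an aryl ring directly on that carbon, gives a lower number than compound 2. A modest move toward a lower number is therefore expected, a 1.6-fold lower number from compound 2 to compound 4 (0.20 log units; within the scatter), with wide uncertainty. Compound 4 is estimated at 80 ug/mL, within a range of 35 ug/mL to 180 ug/mL.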

Compound 4, half-maximal inhibitory concentration: 74.3 ug/mL
Beside the measured number, compound 4's estimate is 1.1-fold (0.03 log units) above it, and the stated range covers the measured number.
By their numbers in this assay, from the lowest: compounds 1, 4, 3 and 2 (each within the scatter of the next, the first and the last beyond it).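

Going by these compounds alone, this is the first matched pair at this position of the five-membered ring: with the ethyl group and the rest of the shared core unchanged, replacing ((naphthalen-1-yl)oxy)methyl with 4-nitrophenyl gives a 1.7-fold lower number from compound 2 to compound 4 (0.23 log units; within the scatter) in this assay. The exchange is a substantial one in structure, replacing two six-membered aromatic rings and their oxygen-containing link with a single six-membered aromatic ring that carries a nitro group, yet compound 2 and compound 4 cannot be told apart in this read-out, so this particular swap shows no clear effect on the number. No supporting measurement bears on this result.

The compounds shown leave open whether an amine or a carboxylic acid in place of the nitro group on the phenyl ring, or a longer chain at the same ring carbon, would give a number beyond the scatter of compound 4. They also leave open whether this swap would give a step of similar size on a core with cyclopropyl in place of ethyl, since compound 3 and compound 4 differ in more than one place.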